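Removing a Methyl From the Fused Ring of Compound 3

The source may hold more compounds than are shown below. What is called first, only, known or untested is meant among the compounds shown, and "the series" means these compounds.

Compound 1 `Fc1ccccc1Cn1cc(CSC(=S)N2CCNCC2)nn1`, compound 2 `COc1cc(Cn2cc(CSC(=S)N3CCNCC3)nn2)cc(OC)c1OC`, compound 3 `Cc1cc(=O)oc2cc(OCCn3cc(CSC(=S)N4CCN(C(=O)OC(C)(C)C)CC4)nn3)ccc12` and the not yet tested compound 4 `CC(C)(C)OC(=O)N1CCN(C(=S)SCc2cn(CCOc3ccc4ccc(=O)oc4c3)nn2)CC1` share a common core and differ in the group attached to it. Their activity is followed in a functional assay on MCF7 cells (Homo sapiens) for inhibition, read by MTT assay, with a stated time of 72 h; on this read-out lower numbers stand for stronger inhibition and higher numbers for weaker inhibition. In this assay compound 1 gives 33200 nM. For compound 2 the result is "not determined" (no result reported). Compound 3 gives 90400 nM, the higher of the two numbers that exist; compound 1 sits lower by a margin beyond the usual scatter, so compound 3 is the weaker inhibitor of that pair.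

Compound 4 is compound 3 with a single change: hydrogen in place of methyl on an aromatic carbon. Within the data shown here, no pair of measured compounds differs by exactly this change, so no measured step guides the expectation; the only anchor is the value of compound 3 itself.

The change is a small one at the edge of the molecule. The step from compound 3 to compound 4 in this assay is expected to be a 1.0-fold lower number from compound 3 to compound 4 (0.00 log units; within the scatter), without a clear direction beyond the scatter. Compound 4 is accordingly estimated at 90000 nM, with a range from 40000 nM to 200000 nM.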

Compound 4, half-maximal inhibitory concentration: 79800 nM
The estimate for compound 4 lay 1.1-fold (0.05 log units) above the measured number; the range from low to high includes it.
By their numbers in this assay, from the lowest: compound 1; then compounds 4 and 3 (each within the scatter of the next).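

In this assay, among these compounds, putting hydrogen in place of methyl gives a 1.1-fold lower number from compound 3 to compound 4 (0.05 log units; within the scatter) and this is the only measured step between compounds that differ in one place. It shows that, on this aromatic carbon opposite the ring oxygen, the methyl can be removed without a change in the number that rises above the usual scatter, so compound 3 and compound 4 cannot be told apart on this read-out. The data at hand offer no independent measurement that would explain this result.

The compounds shown carry only methyl or hydrogen on this carbon, so it remains open whether an amine, a carboxylic acid or a longer chain such as propyl would shift the number in either direction. This single step also cannot show whether the same exchange would behave in the same way in a compound with a different group on the shared core, such as compound 1, for which no matching partner is available.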